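A fluoropyridine takes the place of a difluorophenyl group

The compounds below may be only part of what the source reports. "The series", "measured", "known", "first", "only" and "open" are said of these compounds alone.

Measured so far in an ADME assay on HepG2 cells (Homo sapiens) for cytotoxicity, read by resazurin assay, with a stated time of 48 h; a higher number here means that more compound is needed for the effect, a lower number that less compound is needed:
Compound 1 `O=C(Nc1ccc(F)c(-c2nc3ncc(-c4ccc(F)cc4F)cc3[nH]2)c1)N1CCCC1`: 32400 nM
Compound 2 `O=C(Nc1ccc(F)c(-c2nc3ncc(-c4cccc(F)c4F)cc3[nH]2)c1)N1CCCC1`: > 50000 nM

Compound 2 stands at > 50000 nM, which is a limit of the assay and not a number. The next compound, compound 3 `O=C(Nc1ccc(F)c(-c2nc3ncc(-c4cccnc4F)cc3[nH]2)c1)N1CCCC1`, carries 2-fluoropyridin-3-yl in place of 2,3-difluorophenyl on the same aromatic carbon: 2-fluoropyridin-3-yl in place of 2,3-difluorophenyl on an aromatic carbon. Going by the values given here, the one measured step at this place, 2,3-difluorophenyl in place of 2,4-difluorophenyl, is an at least 1.5-fold higher number from compound 1 to compound 2 (0.18 log units; that floor lies within the scatter). On these data alone, its true size remains unknown, so it supports only a modest expectation: no step beyond the scatter in this assay, and no firm direction. A second limit reading is also quite possible. The estimated value for compound 3 is 42000 nM, with an expected range of 20000 nM to 60000 nM. The expected step is an at least 1.1-fold lower number from compound 2 to compound 3 (0.07 log units; that floor lies within the scatter).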

Compound 3, half-maximal effective concentration: > 50000 nM
Compound 3 gave a limit, no number; the forecaster's own chance of this, stated with the estimate: 55%; middle value at least 1.1-fold (0.07 log units) away from the limit.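

Measured in this assay, 2-fluoropyridin-3-yl in place of 2,4-difluorophenyl gives an at least 1.5-fold higher number from compound 1 to compound 3 (0.18 log units; that floor lies within the scatter), so this place also accepts a six-membered aromatic ring with one hetero atom without a measured number appearing. Compound 3 gives > 50000 nM, which is a limit of the assay and not a number. The step between compound 2 and compound 3 cannot be read, because both readings stop at the same limit: the limit of > 50000 nM in this assay, at which 2 of the 3 values shown sit.

On these data alone, the true distance of compound 2 and compound 3 from compound 1 therefore stays open, and only compound 1 has a number to compare against. The compounds shown also leave open what a quite different group at this place, such as an amine or a carboxylic acid, would give.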